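Furan-2-yl in place of pyridin-3-yl on the shared core

This account rests on a few compounds, and the source may have more. Where it says the series, first, only, none or still open, it means among the compounds named here.

Measured so far:
compound 1, `Oc1ccc(-c2cc(-c3ccco3)nc(-c3ccccc3Cl)c2)cc1`: 4310 nM
compound 2, `Oc1ccc(-c2cc(-c3cccnc3)nc(-c3cccc(Cl)c3)c2)cc1`: 25700 nM

Two compounds share the core of compound 1, a 4-hydroxyphenyl group on it in each. In an ADME assay on HEK293 cells (Homo sapiens) for cytotoxicity, read by CCK-8 assay and cell counting, with a stated time of 2 days (a lower number here means a stronger inhibitor, a higher number a weaker inhibitor), compound 1 gives 4310 nM. In this assay compound 2 gives 25700 nM, the highest of the two numbers; the gap to compound 1 lies beyond the scatter, so compound 2 is the weaker of the pair here.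

Compound 3, `Oc1ccc(-c2cc(-c3cccc(Cl)c3)nc(-c3ccco3)c2)cc1`, has not been measured. It differs from compound 2 in one place: furan-2-yl in place of pyridin-3-yl on an aromatic carbon. Among the measured compounds shown here, no measured pair shows exactly this exchange, so the size of the step is open. For the measured compounds named here, the only guide is compound 1, which also carries a furan-2-yl group and a chlorophenyl group on the same core and gives the lower number.

For compound 3 the number is expected to fall below that of compound 2, because compound 1 gives 4310 nM; the estimated step is a 3.7-fold lower number from compound 2 to compound 3 (0.56 log units; beyond the scatter). The estimate for compound 3 in this assay is 7000 nM, with a range from 2500 nM to 20000 nM.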

Compound 3, half-maximal inhibitory concentration: 2880 nM
Compound 3: middle estimate off by 2.4-fold (0.39 log units), on the high side, within the range that was stated.
By their numbers in this assay, from the lowest: compounds 3 and 1 (each within the scatter of the next); then compound 2.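

The shared core now offers a direct reading of this exchange in this assay: with the 3-chlorophenyl group held in place, furan-2-yl in place of pyridin-3-yl on the aromatic carbon next to the ring nitrogen gives an 8.9-fold lower number from compound 2 to compound 3 (0.95 log units; beyond the scatter) in this pair, so the group at this position can shift the number beyond the scatter. The exchange of 3-chlorophenyl in place of 2-chlorophenyl gives a 1.5-fold lower number from compound 1 to compound 3 (0.18 log units; within the scatter) between these two furan-2-yl compounds, so this pair does not separate the two chlorophenyl groups. The compounds shown offer no measurement that bears on the cause of the step between the furan-2-yl and pyridin-3-yl compounds.

On these data alone, only these two aromatic rings are seen at this position, so it remains open whether an amine such as morpholine, a carboxylic acid or a longer alkyl chain there would stay close to compound 3 or move towards compound 2. As far as these compounds go, the role of the 4-hydroxyphenyl group also remains open, since it is common to all three compounds and a methoxy group in place of its hydroxyl would be needed to read it.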